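Inverting one ring stereocentre in a hydroxamic acid triazole

The compounds below may be only part of what the source reports. "The series", "measured", "known", "first", "only" and "open" are said of these compounds alone.

Compound 1 `O=C(NO)c1cccc(-c2cn([C@@H]3C[C@H](C(=O)O)N(CCCc4ccccc4)C3)nn2)c1`: < 10%
Compound 2 `O=C(NO)c1cccc(-c2cn([C@@H]3C[C@H](CO)N(CCCc4ccccc4)C3)nn2)c1`: < 10%
Compound 3 `O=C(NO)c1ccc(-c2cn([C@@H]3C[C@H](C(=O)O)N(CCCc4ccccc4)C3)nn2)cc1`: < 10%

The three compounds were tested in an assay on Sf9 cells for inhibition of histone deacetylase 11 (Homo sapiens), read by fluorescence, tested at 0.5 uM; on this read-out lower numbers stand for less inhibition and higher numbers for more inhibition at the one concentration tested (going by the name of the read-out). In this assay compound 1 gives < 10%, which is a limit of the assay rather than a number. Compound 2 likewise gives < 10%, a limit. Compound 3 gives < 10%, again a limit. The step that the two limits leave unreadable from compound 1 to compound 2 and the step that the two limits leave unreadable from compound 1 to compound 3 therefore cannot be read in size or direction, because all three values sit at the limit of < 10% in this assay, at which 3 of the 3 values shown sit.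

Compound 4 `O=C(NO)c1cccc(-c2cn([C@@H]3C[C@@H](C(=O)O)N(CCCc4ccccc4)C3)nn2)c1` differs from compound 1 as follows: the two compounds have the same atoms and bonds and differ only in configuration as drawn: 1 of 2 stereo elements differ; a stereocentre at a saturated ring carbon is drawn R in compound 1 and S in compound 4. Within the data shown here, no measured pair tests an inversion of this kind, and the two steps that were measured are themselves unreadable; they only show that changing the carboxy group or moving the hydroxycarbamoyl group leaves the read-out at the limit. Nothing among the shown compounds points to a rise beyond the scatter, so the step that the limit leaves unreadable from compound 1 to compound 4 is expected to be none beyond the scatter. Compound 4 is thus estimated at 5%, within 0% to 15%, most probably reported as a limit once more.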

Compound 4, a percentage reported as inhibition, at one concentration (the size of the read-out at that concentration, not a potency): < 10%
Compound 4 was reported as a limit (the forecaster's own chance of this, stated with the estimate: 85%); the middle value is on the limit's open side.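

In this assay compound 4 gives < 10%, which is a limit and not a number. No step can be read between compound 1 and compound 4, because both values sit at the same limit: the limit of < 10% in this assay, at which 4 of the 4 values shown sit.

The compounds shown leave open whether the configuration at that saturated ring carbon affects the inhibition at all.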